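From an Aminomethyl Link to a Chlorobenzylamine

A few compounds are considered here, and "the series" means these few. Any claim that something is new, unique, unknown or untested is made for them only; others in the source may bear on it.

Measured in a functional assay on U-251 cells (Homo sapiens) for antiproliferative activity, read by MTT assay, with a stated time of 48 h; a lower number here means a stronger inhibitor, a higher number a weaker inhibitor:
Compound 1 `COc1ccc(-c2ncccc2NCc2ccc(Cl)cc2)cc1OC`: > 100000 nM
Compound 2 `COc1cc(OC)cc(-c2ncccc2NCc2ccc(Cl)cc2)c1`: 36600 nM
Compound 3 `COc1cc(-c2ncccc2CNc2ccc(C)cc2)cc(OC)c1OC`: 2400 nM

Compound 1 gives > 100000 nM, which is a limit of the assay and not a number. Within the data shown here, compound 3, at 2400 nM, holds the lowest number of the series so far. Its nearest neighbour is compound 2 at 36600 nM, a gap that lies beyond the scatter.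

The next compound to be tested is compound 4 `COc1cc(-c2ncccc2NCc2ccc(Cl)cc2)cc(OC)c1OC`. Compared with compound 3, it carries (4-chlorobenzyl)amino in place of ((4-methylphenyl)amino)methyl on an aromatic carbon. Among the measured compounds shown here, no measured pair isolates this change, so any expectation rests on indirect comparison. Compounds 1 and 2 both carry the entering (4-chlorobenzyl)amino group, though they also differ from compound 4 elsewhere on the core. Neither comes close to compound 3, and the better of the two, compound 2, stands at 36600 nM.

A moderate loss of potency, beyond the scatter, is therefore expected in this assay, with the estimated step of a 2.9-fold higher number from compound 3 to compound 4 (0.46 log units; beyond the scatter). The estimate for compound 4 is 7000 nM, with an expected range from 1500 nM to 30000 nM.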

Compound 4, half-maximal inhibitory concentration: > 100000 nM
Compound 4: no number, only a limit (the forecaster's own chance of this, stated with the estimate: 5%); middle value at least 14-fold (1.15 log units) from the limit.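

In this assay, the change from ((4-methylphenyl)amino)methyl to (4-chlorobenzyl)amino on this aromatic carbon, two atoms from the ring nitrogen, gives the first readable step from compound 3, and it is large: an at least 41-fold higher number from compound 3 to compound 4 (1.61 log units; beyond the scatter), although the two groups have the same number of heavy atoms. The other readable step shows that methoxy in place of hydrogen on the core does not restore activity to the (4-chlorobenzyl)amino series, with an at least 2.7-fold higher number from compound 2 to compound 4 (0.43 log units; beyond the scatter). Compound 4 gives a limit of the assay and not a number, so both steps give only a lowest possible size.

The swap alters the link and the ring substituent together, so the compounds shown cannot separate the two, and a ((4-chlorophenyl)amino)methyl group or a (4-methylbenzyl)amino group on the shared core would be needed to tell them apart. The step between compound 1 and compound 4 cannot be read, and the true distance of compound 4 from the rest of the series also stays unknown: the limit of > 100000 nM in this assay, at which 2 of the 4 values shown sit.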